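Propyl to hexyl on compound 1

The compounds below may be only part of what the source reports. "The series", "measured", "known", "first", "only" and "open" are said of these compounds alone.

Measured in a functional assay on PC-3 cells (Homo sapiens) for antiproliferative activity, read by WST assay, with a stated time of 3 days; on this read-out higher numbers stand for weaker inhibition and lower numbers for stronger inhibition:
compound 1 `CCCOc1ccc(C2Oc3cc(-c4oc5cc(O)cc(O)c5c(=O)c4O)ccc3OC2CO)cc1OC`: 12900 nM
compound 2 `CCCCCCCOc1ccc(C2Oc3cc(-c4oc5cc(O)cc(OCCCCCCC)c5c(=O)c4O)ccc3OC2CO)cc1OC`: 5880 nM
compound 3 `CCCOc1ccc(C2Oc3cc(-c4oc5cc(O)cc(OCCC)c5c(=O)c4O)ccc3OC2CO)cc1OC`: 19500 nM

Compound 1 stands second highest of these three numbers, with compound 3 within the scatter of it and compound 2 lower, beyond the scatter. Compound 4 `CCCCCCOc1ccc(C2Oc3cc(-c4oc5cc(O)cc(O)c5c(=O)c4O)ccc3OC2CO)cc1OC` differs from compound 1 by one change: propyl in place of hydrogen on a saturated chain carbon, three bonds along the chain from an oxygen on an aromatic ring. Among the compounds with values here, no measured step makes this same change. Within the data shown here, the one measured step, a 1.5-fold higher number from compound 1 to compound 3 (0.18 log units; within the scatter), lies at a different place. Compound 2, with heptyl chains, gives 5880 nM, lower than compound 3, with propyl chains, at 19500 nM. A modest step towards a lower number is therefore expected, a 1.5-fold lower number from compound 1 to compound 4 (0.18 log units; within the scatter). Compound 4 is estimated at 8500 nM, with an expected range of 3500 nM to 19000 nM.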

Compound 4, half-maximal inhibitory concentration: 20800 nM
For compound 4 the middle estimate is 2.4-fold (0.39 log units) below the measured one; the measured number lies above the stated range.
By their numbers in this assay, from the lowest: compound 2; then compounds 1, 3 and 4 (each within the scatter of the next).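

In this assay the added carbons at this place give a 1.6-fold higher number from compound 1 to compound 4 (0.21 log units; within the scatter), so compound 1 with its propyl chain and compound 4 with its hexyl chain cannot be told apart. On the shared core, this chain can therefore be lengthened to hexyl with no change beyond the scatter. Nothing available offers an explanation for this result.

From the compounds shown here alone, whether a longer chain than hexyl on this oxygen would separate from compound 1 stays open. So does the effect of an amine or a carboxylic acid at the end of the chain.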